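One Carbon More on the Acid Chain

The compounds below may be only part of what the source reports. "The series", "measured", "known", "first", "only" and "open" are said of these compounds alone.

In an ADME assay on microsomes from liver (Mus musculus) for metabolic stability, read by LC-MS, using NADPH, with a stated time of 60 min, tested at 1 uM (on this read-out lower numbers stand for a shorter-lived compound and higher numbers for a longer-lived compound), compound 1 (`O=S(=O)(c1cccc(C(F)(F)F)c1)N1CCc2ccc(-c3cc(F)cc(OC(F)F)c3)cc21`) gives 0.19 h and compound 2 (`O=C(O)CC1CN(S(=O)(=O)c2cccc(C(F)(F)F)c2)c2cc(-c3cc(F)cc(OC(F)F)c3)ccc21`) gives 0.76 h as the higher of the two numbers. With only these two measured, compound 2 stands at the top of a very short list.

Compound 3 (`O=C(O)CCC1CN(S(=O)(=O)c2cccc(C(F)(F)F)c2)c2cc(-c3cc(F)cc(OC(F)F)c3)ccc21`) differs from compound 2 in one place: carboxymethyl in place of carboxy on a saturated chain carbon bound to a saturated ring carbon describes the change. It is carboxymethyl in place of carboxy on a saturated chain carbon bound to a saturated ring carbon, so that carboxymethyl becomes 2-carboxyethyl.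

For the measured compounds named here, only one measured step bears on this. It is a 4.0-fold higher number from compound 1 to compound 2 (0.60 log units; beyond the scatter) and it came from carboxymethyl in place of hydrogen on a saturated ring carbon. Going by the values given here, that step shows what adding the whole group did, and no measured pair shows what lengthening the chain does. The edit here is smaller, so only a modest shift is expected, with no clear direction and none beyond the scatter.

The estimated step is a 1.1-fold lower number from compound 2 to compound 3 (0.04 log units; within the scatter) and this is an expectation only. In this assay compound 3 is estimated to read 0.7 h with 0.3 h to 1.6 h as its likely range.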

Compound 3, half-life: 0.408 h
For compound 3 the middle estimate is 1.7-fold (0.23 log units) above the measured one, within the range that was stated.
By their numbers in this assay, from the lowest: compound 1; then compounds 3 and 2 (each within the scatter of the next).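

In this assay, going from carboxymethyl to 2-carboxyethyl on the saturated ring carbon gives a 1.9-fold lower number from compound 2 to compound 3 (0.27 log units; within the scatter), so this read-out does not separate these two acid chains. Set against hydrogen on that same ring carbon, the longer chain shows a 2.1-fold higher number from compound 1 to compound 3 (0.33 log units; beyond the scatter), which means that a second acid chain, and not carboxymethyl alone, now stands beyond the scatter from the hydrogen compound, though only modestly. Nothing measured here explains how either chain relates to the half-life, and the numbers alone record the outcome without giving its cause.

From the compounds shown here alone, it remains open whether the carboxylic acid itself is needed at this position, or whether a methyl ester, a primary amide or an amine at the end of the same chain would read the same way. Going by these compounds, it is also open whether a still longer chain ending in the acid would stay within the scatter of these two or move clearly away from them.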